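The source may report more compounds than this note shows. Statements on the series, on what has been measured and on what is new or still open speak of the compounds shown alone.

Working notes on the series.

Compound 1 `ClCc1ccc(Cn2cnc3c(Cl)ncnc32)cc1` is the reference point: in a functional assay on CAKI-1 cells (Homo sapiens) for cytotoxicity, read by sulforhodamine B assay, with a stated time of 48 h (a higher number here means that more compound is tolerated, a lower number that less compound is tolerated), compound 1 gives 2390 nM. Compound 2 `Nc1nc(Cl)c2ncn(Cc3ccc(CCl)cc3)c2n1` carries one change relative to compound 1, (amino in place of hydrogen on an aromatic carbon), and in this assay compound 2 gives 34700 nM. The step is a 15-fold higher number from compound 1 to compound 2 (1.16 log units; beyond the scatter), so the amino group moves the number a long way in the direction of more compound being tolerated.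

Compound 3 `ClCc1ccccc1Cn1cnc2c(Cl)ncnc21` has the same atoms as compound 1, joined differently; the difference between the two cores is not broken down here. In this assay compound 3 gives 9330 nM, which stands beyond the scatter from both compound 1 and compound 2, falling in between them.

Compound 4 `Nc1nc(Cl)c2ncn(Cc3ccccc3CCl)c2n1` is not yet measured. Relative to compound 3 it carries amino in place of hydrogen on an aromatic carbon, the same change as the one from compound 1 to compound 2: the place lines agree word for word. Within the shown compounds the change occurs only twice, so the one measured step is the whole basis. Taking that step as the guide, compound 4 is expected to lie near 90000 nM in this assay, with the step of a 9.6-fold higher number from compound 3 to compound 4 (0.98 log units; beyond the scatter) expected because compound 3 already gives 9330 nM and the amino step on compound 1 produced a 15-fold higher number from compound 1 to compound 2 (1.16 log units; beyond the scatter). For the measured compounds named here, the expected range for compound 4 is 25000 nM to 300000 nM, wider than the usual scatter since only one prior step supports the transfer.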

Compound 4, concentration lethal to 50% of the cells: 50100 nM
Compound 4: middle estimate off by 1.8-fold (0.25 log units), on the high side; low and high end bracket the measured number.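

On the core of compound 3, amino in place of hydrogen on an aromatic carbon again moves the number in this assay towards more compound being tolerated, a 5.4-fold higher number from compound 3 to compound 4 (0.73 log units; beyond the scatter), so the direction of the change carries from one core to the other in both available pairs. The size does not carry over unchanged, and the transfer therefore holds for direction but not for magnitude: the same change on two cores in this assay, a 15-fold higher number (1.16 log units; beyond the scatter) from compound 1 to compound 2 and a 5.4-fold higher number (0.73 log units; beyond the scatter) from compound 3 to compound 4, 2.7-fold (0.43 log units) apart, beyond the scatter of two such steps
Two pairs show only that the size of this step depends on the core to some degree; they do not give a rule for predicting the step on a further core, and they do not identify which feature of the two cores accounts for the gap.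

The compounds shown leave open whether another group at the same place, such as a methylamino group or a methoxy group, would shift the number as amino does, and whether the step on either core is specific to amino. They also leave open how the step would behave if the chloromethyl group on the benzyl ring gave way to a hydroxymethyl group or a plain methyl group.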